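This account rests on a few compounds, and the source may have more. Where it says the series, first, only, none or still open, it means among the compounds named here.

Three compounds carrying the shared core of compound 1, `CC(C)COC(=O)Nc1ccc([Se][Se]c2ccc(NC(=O)OCC(C)C)cc2)cc1`, have been tested in a functional assay on HT-29 cells (Homo sapiens) for cytotoxicity, read by MTT assay, with a stated time of 72 h; on this read-out higher numbers stand for lower toxicity in this test and lower numbers for higher toxicity in this test. Compound 1 gives 77400 nM. Compound 2, `N#C[Se]c1ccc(NC(=O)Oc2ccc(F)cc2)cc1`, gives 66500 nM in this assay. Compound 3, `C=CCOC(=O)Nc1ccc([Se]C#N)cc1`, gives 72800 nM in this assay. The three numbers sit close together: the gap from compound 3 to compound 1 and the gap from compound 3 to compound 2 both lie within the usual scatter, so nothing separates these compounds on this read-out.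

Compound 4, `N#C[Se]c1ccc(NC(=O)OCc2ccccc2)cc1`, has not yet been measured. It differs from compound 3 in one place: phenyl in place of vinyl on a saturated chain carbon bound to an oxygen next to a carbonyl group. Within the data shown here, no measured pair shows what such a change does here, and the three measured compounds, though different in their side groups, all land in the same narrow band. On that basis, the step from compound 3 to compound 4 in this assay is expected to be small, in no particular direction, and not beyond the scatter, namely a 1.0-fold lower number from compound 3 to compound 4 (0.02 log units; within the scatter). Compound 4 is therefore estimated to give about 70000 nM in this assay, with a plausible range from 35000 nM to 140000 nM.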

Compound 4, concentration lethal to 50% of the cells: 69100 nM
Compound 4: the middle estimate sits 1.0-fold (0.01 log units) above what was measured; the range from low to high includes it.
By their numbers in this assay, from the lowest: compounds 2, 4, 3 and 1 (each within the scatter of the next).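

Among these compounds, this is the first pair in the set that differs in one place, and in this assay it gives a 1.1-fold lower number from compound 3 to compound 4 (0.02 log units; within the scatter). On a saturated chain carbon bound to an oxygen next to a carbonyl group, then, replacing vinyl, with 2 heavy atoms, by phenyl, with 6 heavy atoms and an aromatic ring, leaves the read-out within the scatter for this pair. No supporting data bear on why this step is so small.

The compounds shown leave open whether other groups at this place, such as an amine, a carboxylic acid or a longer chain, would also stay within the scatter. A single pair also cannot say whether phenyl in place of vinyl would give a similarly small step on another compound with the shared core.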